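Phenyl in Place of Cyano on the Aryl Piperazine

The compounds below may be only part of what the source reports. "The series", "measured", "known", "first", "only" and "open" are said of these compounds alone.

Measured in a functional assay on aorta for antagonist activity at Alpha-1D adrenergic receptor (Rattus norvegicus); a higher number here means weaker binding, a lower number tighter binding:
compound 1 `COc1ccccc1N1CCN(CCCSc2ccccc2C(=O)N(C)C)CC1` gives 12.6 nM
compound 2 `CN(C)C(=O)c1cccnc1NCCCN1CCN(c2ccccc2C#N)CC1` gives 10 nM

Compound 2 has the lower of the two numbers in this assay, but compound 1 sits within the scatter of it, so the two cannot be ranked. Compound 3 `CN(C)C(=O)c1cccnc1NCCCN1CCN(c2ccccc2-c2ccccc2)CC1` differs from compound 2 in one place: phenyl in place of cyano on an aromatic carbon. Within the data shown here, no measured pair shows this change, so its effect is unknown; a modest weakening is expected, since a change of this size rarely leaves the number untouched. For compound 3 the expected value is 25 nM, with a range from 6 nM to 100 nM, meaning an estimated step of a 2.5-fold higher number from compound 2 to compound 3 (0.40 log units; beyond the scatter).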

Compound 3, dissociation constant: 63.1 nM
The estimate for compound 3 lay 2.5-fold (0.40 log units) below the measured number; the range from low to high includes it.
By their numbers in this assay, from the lowest: compounds 2 and 1 (each within the scatter of the next); then compound 3.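

Replacing cyano with phenyl on this aromatic carbon, ortho to a large group, weakens binding in this assay and gives a 6.3-fold higher number from compound 2 to compound 3 (0.80 log units; beyond the scatter). This position therefore responds to the group it carries, although compound 3 still gives a measurable 63.1 nM. Nothing shown explains the loss. From the compounds shown here alone, whether a fluorine atom, a methyl group or a pyridine ring at this place would keep the number close to that of compound 2 remains open, as does whether the same change would have a similar effect on a different core.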